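Trimming the Ring on a Brominated Core

The source may report more compounds than this note shows. Statements on the series, on what has been measured and on what is new or still open speak of the compounds shown alone.

Of the compounds shown here, three have been measured in an ADME assay on microsomes from liver (Homo sapiens) for metabolic stability, tested at 2.5 uM; a higher number here means faster removal of the compound, a lower number slower removal. Compound 1 `Fc1cc(Cl)ccc1-c1ccc(Cn2nnc3ccccc32)cc1` gives 0.4 mL/min/g, and compound 2 `Fc1cc(Cl)ccc1-c1ccc(Cn2nnc3c(C(F)(F)F)cccc32)cn1` gives 0.04 mL/min/g. Compound 3 `Brc1cccc2c1nnn2CC1CCC1` gives 8.7 mL/min/g, the highest number of the three, and its distance from both compound 1 and compound 2 is well beyond the usual scatter of this assay, so compound 3 is cleared fastest by a clear margin.

The next compound, compound 4 `CCCn1nnc2c(Br)cccc21`, keeps the brominated core of compound 3 and alters only the group on the saturated chain carbon bound to an aromatic nitrogen: ethyl in place of cyclobutyl on a saturated chain carbon bound to an aromatic nitrogen. Among the measured compounds shown here, no pair of measured compounds shows exactly this change, so there is no measured step to lean on. The expectation is that a smaller, ring-free group on that position leaves this assay reading somewhat lower than compound 3, though a shift that small could easily stay inside the scatter. In this assay compound 4 is expected to give about 5 mL/min/g, with a plausible range from 2 mL/min/g to 12 mL/min/g. That expectation corresponds to a step of a 1.7-fold lower number from compound 3 to compound 4 (0.24 log units; within the scatter), a modest move toward slower removal that may or may not clear the scatter.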

Compound 4, intrinsic clearance in a liver preparation (reported as CLH), per the amount of preparation that the assay uses: 4.7 mL/min/g
The estimate for compound 4 lay 1.1-fold (0.03 log units) above the measured number; measured number inside the range.
By their numbers in this assay, from the lowest: compound 2; then compound 1; then compounds 4 and 3 (each within the scatter of the next).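

Compounds 3 and 4 are the only pair shown that differ in one place, so they give the first direct look at this position: ethyl in place of cyclobutyl on a saturated chain carbon bound to an aromatic nitrogen. In this assay, this change gives a 1.9-fold lower number from compound 3 to compound 4 (0.27 log units; within the scatter), a step within the usual scatter of repeated measurements, so this pair shows no difference that the assay can resolve, even though the four-membered ring is gone and the group is smaller. No accompanying measurement bears on why the ring can be lost with so little visible consequence in this pair.

As far as these compounds go, it remains open whether a different kind of group on this carbon, such as an amine, a carboxylic acid or a longer chain like hexyl, would carry the reading beyond the scatter in either direction. From the compounds shown here alone, it is also open whether ethyl in place of cyclobutyl would behave the same way on a core other than the brominated one shared by compound 3 and compound 4.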